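This account rests on a few compounds, and the source may have more. Where it says the series, first, only, none or still open, it means among the compounds named here.

Measured compounds:

Compound 1 `COc1cccc(N2C(=O)COc3ccc(-c4cnc(Cl)c(NS(=O)(=O)c5ccc(F)cc5)c4)cc32)c1` gives only a limit in a functional assay on HepG2 cells (Homo sapiens) for antiproliferative activity, read by MTT assay, with a stated time of 72 h (a higher number here means a weaker inhibitor, a lower number a stronger inhibitor), > 40000 nM.
Compound 2 `CC(C)N1C(=O)COc2ccc(-c3cnc(Cl)c(NS(=O)(=O)c4ccc(F)cc4)c3)cc21` gives 21500 nM in this assay.
Compound 3 `COc1cccc(N2C(=O)COc3ccc(-c4cccc(NS(=O)(=O)c5ccc(F)cc5)c4)cc32)c1` gives only a limit in this assay, > 40000 nM.

Going by the values given here, the one counted step in this assay runs from compound 1 to compound 2, where the change is isopropyl in place of 3-methoxyphenyl on an amide-type nitrogen in a ring. The step is an at least 1.8-fold lower number from compound 1 to compound 2 (0.26 log units; that floor lies within the scatter); its size is bounded only from below, because of the limit of > 40000 nM in this assay, at which 2 of the 3 values shown sit. Compound 3 carries a core that differs from the core of compound 1, but that difference between the two cores is not broken down here.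

Compound 4 `CC(C)N1C(=O)COc2ccc(-c3cccc(NS(=O)(=O)c4ccc(F)cc4)c3)cc21` remains to be measured in this assay. It differs from compound 3 by isopropyl in place of 3-methoxyphenyl on an amide-type nitrogen in a ring, the same change, at a place described in the same words as for the step from compound 1 to compound 2.

For compound 4 the expected step is an at least 1.4-fold lower number from compound 3 to compound 4 (0.15 log units; that floor lies within the scatter), resting on the step from compound 1 to compound 2 being an at least 1.8-fold lower number from compound 1 to compound 2 (0.26 log units; that floor lies within the scatter) and on compound 3 giving only the limit > 40000 nM. The estimate for compound 4 in this assay is 28000 nM, with a range expected from 12000 nM to 60000 nM.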

Compound 4, half-maximal inhibitory concentration: > 40000 nM
Compound 4: only a limit was reported (the forecaster's own chance of this, stated with the estimate: 40%); middle value at least 1.4-fold (0.15 log units) away from the limit.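

Compound 3 and compound 4 each give only a limit in this assay, so the step between them cannot be read: the limit of > 40000 nM in this assay, at which 3 of the 4 values shown sit.

The compounds shown leave open whether isopropyl in place of 3-methoxyphenyl lowers the number at all on the core of compound 3, and how any such step compares with that on the core of compound 1.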